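Ethoxy for fluoro on the phenoxy ring, calcium flux

A few compounds are considered here, and "the series" means these few. Any claim that something is new, unique, unknown or untested is made for them only; others in the source may bear on it.

Series notes. Going by the values given here, in a functional assay on cells for agonist activity at Free fatty acid receptor 1 (Mus musculus), read by FLIPR and calcium flux, with a stated time of 100 s (a higher number here means that more compound is needed for the effect, a lower number that less compound is needed), compound 2 `O=C(O)C[C@@H]1CCCN1c1ccc(Oc2ccccc2F)cc1` gives 6900 nM, the only measured number in the set. Compound 1 `O=C(O)C[C@@H]1CCCN1c1ccc(Oc2ccccc2)cc1` reaches only a limit there, > 16000 nM. Among the compounds with values here, the one measured step is an at least 2.3-fold lower number from compound 1 to compound 2 (0.36 log units; beyond the scatter); its size rests on the limit of > 16000 nM in this assay, at which 1 of the 2 values shown sits, and so is known only as a floor. Compound 3 `CCOc1ccccc1Oc1ccc(N2CCC[C@H]2CC(=O)O)cc1` differs from compound 2 by ethoxy in place of fluoro on an aromatic carbon. The fluoro step from compound 1 to compound 2 touches the same aromatic carbon but a different group, so it bears on the new step only by showing that substitution at this carbon moved the number beyond the scatter; it gives no direction for ethoxy. A step of modest size, most likely toward a lower number, is expected, with no change beyond the scatter also plausible. Compound 3 is therefore estimated at 4000 nM, range 1500 nM to 12000 nM, which means an expected step of a 1.7-fold lower number from compound 2 to compound 3 (0.24 log units; within the scatter).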

Compound 3, half-maximal effective concentration: > 33000 nM
Compound 3: a limit, no number; the forecaster's own chance of this, stated with the estimate: 10%; middle value at least 8.2-fold (0.91 log units) away from the limit.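

In this assay, the lower number seen with fluoro at this aromatic carbon, ortho to a large group, does not carry over to ethoxy: the change gives an at least 4.7-fold higher number from compound 2 to compound 3 (0.67 log units; beyond the scatter). So the outcome at this carbon depends on which group sits there, and the fluoro result cannot be extended to the larger ethoxy. Compound 3 reaches only a limit, > 33000 nM, and the step between compound 1 and compound 3 cannot be read, as both of its ends are limits.

Still open, going by these compounds, is whether the higher number follows the heavy-atom count, 3 for ethoxy against 1 for fluoro, or the oxygen that ethoxy brings. Chloro or methoxy at the same aromatic carbon would bear on this, and compound 2 remains the only measured number against which to compare them.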